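Basic amine ring size on the shared core

The source may hold more compounds than are shown below. What is called first, only, known or untested is meant among the compounds shown, and "the series" means these compounds.

Compound 1 `CN1CCCCC(n2nc(Cc3ccc(Cl)cc3)c3ccccc3c2=O)C1`: 158 nM
Compound 2 `COC(=O)c1ccc(Cc2nn(C[C@H]3CCCN3C)c(=O)c3ccccc23)cc1`: > 1990 nM

Among the compounds with values here, in an assay for binding affinity to Alpha-1A adrenergic receptor (Homo sapiens) (on this read-out lower numbers stand for stronger inhibition and higher numbers for weaker inhibition), compound 1 gives 158 nM, the only true number recorded so far. Compound 2 sits at the limit of > 1990 nM in this assay, at which 1 of the 2 values shown sits, which is a limit of the assay and not a number. Compound 3 `CN1CCC(n2nc(Cc3ccc(Cl)cc3)c3ccccc3c2=O)CC1` has not yet been measured. It differs from compound 1 in one place: 1-methylpiperidin-4-yl in place of 1-methylazepan-3-yl on an aromatic nitrogen. Within the data shown here, no step between measured compounds exists to guide the size. The step of a 1.6-fold higher number from compound 1 to compound 3 (0.20 log units; within the scatter) is expected to be a small loss, near the scatter. Compound 3 is estimated at 250 nM, within 60 nM to 1000 nM.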

Compound 3, inhibition constant: 15.9 nM
Beside the measured number, compound 3's estimate is 16-fold (1.20 log units) above it; the whole stated range lies above it.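

In this assay, the change to 1-methylpiperidin-4-yl gives a 9.9-fold lower number from compound 1 to compound 3 (1.00 log units; beyond the scatter). The read-out at this position on the aromatic nitrogen therefore depends on the amine ring itself, with the 4-chlorobenzyl group and the rest of the shared core unchanged. Nothing at hand accounts for the size of this step.

Ring size and attachment point change together in this pair, so their contributions cannot be separated. Also open, as far as these compounds go, is how a 1-methylpyrrolidin-3-yl ring or a piperidin-4-yl ring with a free amine hydrogen would read at this position.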